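From Pyridin-3-yl to 3-Chlorophenyl at the Assay Limit

The source may report more compounds than this note shows. Statements on the series, on what has been measured and on what is new or still open speak of the compounds shown alone.

Of the compounds shown here, three sharing one core have been tested in an ADME assay on BJ cells (Homo sapiens) for cytotoxicity, with a stated time of 72 h; a lower number here means that less compound is needed, a higher number that more compound is needed for the effect. Compound 1 (`Cc1cc(NC(=O)Nc2ccc(C)c(Cl)c2)c2ccccc2n1`) gives > 25000 nM, which is a limit of the assay and not a number. Compound 2 (`Cc1cc(NC(=O)Nc2ccc(O)cc2)c2ccccc2n1`) gives > 25000 nM, again a limit. Compound 3 (`Cc1cc(NC(=O)Nc2cccnc2)c2ccccc2n1`) gives > 25000 nM, also a limit, so it has no number of its own and stands level with the other two only in sharing that limit.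

Compound 4 (`Cc1cc(NC(=O)Nc2cccc(Cl)c2)c2ccccc2n1`), not yet measured, carries 3-chlorophenyl in place of pyridin-3-yl on an amide-type nitrogen. Among the measured compounds shown here, one measured step touches the same place, a step that the two limits leave unreadable from compound 2 to compound 3, and it gives no size to carry over. The broader evidence is the limit of > 25000 nM in this assay, at which 3 of the 3 values shown sit. That includes compound 1, which already holds chlorine in this part of the structure. Nothing measured therefore points to a change in this assay, in either direction. The estimated step of a number no higher from compound 3 to compound 4 (the limit leaves the size open) is expected to stay within the scatter. For compound 4 the estimated value is 25000 nM, with an expected range from 12000 nM to 50000 nM, and a report as a limit once more is the likeliest outcome.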

Compound 4, half-maximal effective concentration: > 25000 nM
Compound 4 was reported as a limit; the forecaster's own chance of this, stated with the estimate: 85%; the middle value sits exactly at the limit.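

Compound 4 gives > 25000 nM in this assay, again a limit of the assay, so no new step can be read between compound 4 and compound 1, compound 2 or compound 3. The compounds shown leave open at what concentration any of them would reach the half-maximal effect, and whether the group on the amide-type nitrogen matters here at all: the limit of > 25000 nM in this assay, at which 4 of the 4 values shown sit.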